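One Substituent Swap, Three Starting Points Level at the Floor

The source may report more compounds than this note shows. Statements on the series, on what has been measured and on what is new or still open speak of the compounds shown alone.

Compound 1, `COC[C@@H]1CCCN1C(=O)C1CCCN1c1cc(Nc2cccc(Br)c2)ncn1`: 0%
Compound 2, `Cc1cccc(Oc2ccnc(N3CCC[C@H]3C(=O)NCCCn3ccnc3)n2)c1`: 0%
Compound 3, `Clc1ccc2sc(CN3CCN(c4ncnc5c4CN(Cc4ccccc4)CC5)CC3)cc2c1`: 0%

Of the compounds shown here, three have been measured in an assay on isolated protein for inhibition of Ephrin type-B receptor 4 (Homo sapiens), read by HTRF, tested at 10 uM; on this read-out higher numbers stand for more inhibition at the one concentration tested (going by the name of the read-out) and lower numbers for less inhibition. Compound 1 gives 0%, compound 2 gives 0%, and compound 3 gives 0%. Compound 3 therefore stands level with compound 1 and with compound 2 at the digits shown, and none of the three differs from another by more than the usual scatter. For the measured compounds named here, no pair among them differs in a single place, so no step between measured compounds is available.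

Compound 4, `O=C(CN1CCN(c2ncnc3c2CN(Cc2ccccc2)CC3)CC1)Nc1cc(F)ccc1F`, has not yet been measured in this assay . It differs from compound 3 as follows: (2,5-difluorophenyl)carbamoyl in place of 5-chloro-1-benzothiophen-2-yl on a saturated chain carbon bound to an amine nitrogen in a ring. Going by the values given here, with nothing among the measured compounds to suggest that any change at this position moves the read-out, and with every measured value sitting at the floor, the expected step from compound 3 to compound 4 is a number 3 percentage points higher from compound 3 to compound 4 (within the scatter), that is, nothing beyond the scatter in either direction. Compound 4 is accordingly estimated to give 3% in this assay , with a range from 0% to 15%, its lower end fixed by the floor of the read-out.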

Compound 4, a percentage reported as inhibition, at one concentration (the size of the read-out at that concentration, not a potency): 0%
Beside the measured number, compound 4's estimate is 3 percentage points above it; the measured number falls inside the stated range.
By their numbers in this assay, from the lowest: compounds 1, 2, 3 and 4 (each within the scatter of the next).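

Putting (2,5-difluorophenyl)carbamoyl in place of 5-chloro-1-benzothiophen-2-yl on a saturated chain carbon bound to an amine nitrogen in a ring gives, in this assay, no change at the digits printed from compound 3 to compound 4 (within the scatter), the only single-place comparison among the compounds shown. At this position, then, trading two fused aromatic rings for a single aromatic ring with a carbamoyl link, which brings a hydrogen-bond donor, does not lift the read-out from the bottom of its scale, where compound 3 and compound 4 both stand, so the step cannot tell the two groups apart. Nothing further is on hand to explain this flat result.

As far as these compounds go, it remains open whether any group at this position can raise inhibition at all, for instance an amine, a carboxylic acid or a longer chain in place of the (2,5-difluorophenyl)carbamoyl. From the compounds shown here alone, it also remains open whether the two groups compared here would differ on a compound that already gives a read-out above the bottom of the scale.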